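This account rests on a few compounds, and the source may have more. Where it says the series, first, only, none or still open, it means among the compounds named here.

Two members of the series have numbers in an ADME assay on membranes from Cortex for displacement of a labelled ligand from Adrenergic receptor alpha-1 (Rattus norvegicus), read by radioligand binding, with a stated time of 60 min; on this read-out higher numbers stand for weaker inhibition and lower numbers for stronger inhibition. Compound 1 `c1ccc(-c2c3c(nn2C2CC2)CCNCC3)cc1` gives 600 nM in this assay. Compound 2 `Cc1ccc(-c2c3c(nn2C(C)C)CCNCC3)cc1` gives 4 nM in this assay, the lower of the two numbers, and its gap to compound 1 lies beyond the scatter; the two structures differ in more than one place, so nothing is said here about which change carries that gap.

Compound 3 `CC(C)n1nc2c(c1-c1ccc(F)cc1)CCNCC2` has not yet been measured in this assay. It differs from compound 2 by fluoro in place of methyl on an aromatic carbon. Among the measured compounds shown here, no measured pair shows this same change, so no step from the data can be carried over. The expected step in this assay is a small rise in the number, of a size near the scatter, given as a 2.5-fold higher number from compound 2 to compound 3 (0.40 log units; beyond the scatter). For compound 3 the estimated number in this assay is 10 nM, with a range from 3 nM to 40 nM.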

Compound 3, inhibition constant: 170 nM
Estimate against measurement, compound 3: 17-fold (1.23 log units) below; the measured number lies above the stated range.
By their numbers in this assay, from the lowest: compound 2; then compound 3; then compound 1.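

Among the compounds shown here, this is the first comparison that differs in one place only. In this assay, fluoro in place of methyl on an aromatic carbon, para to a large group, gives a 43-fold higher number from compound 2 to compound 3 (1.63 log units; beyond the scatter), so the number at this position depends strongly on which of these two groups is present. The data offer no explanation for a step of this size.

As far as these compounds go, whether other groups at this position stay near compound 2 or near compound 3 remains open; chloro, ethyl, methoxy or an amine there would begin to answer that. Compound 1 differs from both other compounds in more than one place, so the separate contributions of its cyclopropyl group and its unsubstituted aromatic ring cannot be read.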